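This account rests on a few compounds, and the source may have more. Where it says the series, first, only, none or still open, it means among the compounds named here.

Working notes on the series, starting from compound 1 `O=c1ccn([C@H]2CC[C@@H](COP(=O)(O)Oc3cccnc3)O2)c(=O)[nH]1`, compound 2 `O=c1ccn([C@H]2CC[C@@H](COP(=O)(O)Oc3ccccc3)O2)c(=O)[nH]1` and compound 3 `Cc1cn([C@H]2C[C@H](N=[N+]=[N-])[C@@H](COP(=O)(O)Oc3ccc(Br)cc3)O2)c(=O)[nH]c1=O`. In a physicochemical assay for metabolic stability, read by HPLC (a lower number here means that the compound disappears faster, a higher number that the compound lasts longer), compound 2 gives 25.1 h, within the scatter of compound 1 at 50.2 h. Compound 3 gives 7.97 h, a lower number than that of compound 2 and beyond the scatter of it. Going by the values given here, compound 3 differs from compound 2 in more than one place, so it offers no clean step for the present question.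

The next change leads to compound 4 `O=c1ccn([C@H]2CC[C@@H](COP(=O)(O)Oc3ccncc3)O2)c(=O)[nH]1`: pyridin-4-yl in place of phenyl on an oxygen. In words, pyridin-4-yl stands in place of phenyl on an oxygen whose other neighbour is phosphorus.

Among the compounds with values here, only one measured step bears on this change, the exchange between pyridin-3-yl and phenyl on the same oxygen: a 2.0-fold lower number from compound 1 to compound 2 (0.30 log units; within the scatter). Within the data shown here, that step stays within the scatter, and no measured compound carries pyridin-4-yl, so the evidence is thin. No step beyond the scatter is therefore expected in this assay, and the expected step is a 1.4-fold higher number from compound 2 to compound 4 (0.14 log units; within the scatter). The middle of the estimate leans slightly towards the pyridin-3-yl compound, as both groups hold a ring with one hetero atom.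

For compound 4 the estimated half-life is 35 h, with an expected range of 14 h to 90 h.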

Compound 4, half-life: 23.6 h
Compound 4: the middle estimate sits 1.5-fold (0.17 log units) above what was measured, and the stated range covers the measured number.
By their numbers in this assay, from the lowest: compound 3; then compounds 4, 2 and 1 (each within the scatter of the next, the first and the last beyond it).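

In this assay, pyridin-4-yl in place of phenyl on an oxygen whose other neighbour is phosphorus gives a step within the scatter (a 1.1-fold lower number from compound 2 to compound 4 (0.03 log units; within the scatter)), so on this oxygen the two groups cannot be told apart. Going by these compounds alone, the exchange of the two pyridine groups gives the first step at this position that passes beyond the scatter (a 2.1-fold lower number from compound 1 to compound 4 (0.33 log units; beyond the scatter)), which shows that where the ring holds its nitrogen may count for more here than whether it holds one at all, although the step is modest and compound 2 stays within the scatter of both pyridine compounds. Nothing measured on these compounds accounts for this result.

The compounds shown leave open how the half-life responds when an amine or a carboxylic acid is carried on the ring on this oxygen, or when a longer alkyl chain stands there in place of the ring. They also leave open whether the step between pyridin-3-yl and pyridin-4-yl would hold on another core, such as that of compound 3.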